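Two Carbons More on a Long Lipid Chain

The source may hold more compounds than are shown below. What is called first, only, known or untested is meant among the compounds shown, and "the series" means these compounds.

Compound 1 `CCCCCCCCCCCCCCCCSCC(COP(=O)(O)OP(=O)(O)OC[C@H]1OC(n2ccc(N)nc2=O)[C@@H](O)[C@@H]1O)OC(=O)CCCCCCCCCCCCC` and compound 2 `CCCCCCCCCCCCCCCCCCSCC(COP(=O)(O)OP(=O)(O)OC[C@H]1OC(n2ccc(N)nc2=O)[C@@H](O)[C@@H]1O)OC(=O)CCCCCCCCCCC` share one core carrying two long chains. In an ADME assay for solubility (on this read-out higher numbers stand for higher solubility and lower numbers for lower solubility), compound 1 gives > 53000000 nM, which is a limit of the assay rather than a number. In this assay compound 2 gives > 54000000 nM, also a limit, so compound 2 stands at the top of what this assay reports. Compound 3 `CCCCCCCCCCCCCCCCCCSCC(COP(=O)(O)OP(=O)(O)OC[C@H]1OC(n2ccc(N)nc2=O)[C@@H](O)[C@@H]1O)OC(=O)CCCCCCCCCCCCC` differs from compound 2 by ethyl in place of hydrogen on a saturated chain carbon, ten or more bonds along the chain from a carbonyl carbon. For the measured compounds named here, no measured step covers such a change; since compound 2 already sits at the limit of > 54000000 nM in this assay, at which 1 of the 2 values shown sits, the step from compound 2 to compound 3 is expected to be none beyond the scatter, a number no higher from compound 2 to compound 3 (the limit leaves the size open). Compound 3 is therefore expected to give 54000000 nM, between 20000000 nM and 60000000 nM.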

Compound 3, solubility: > 62000000 nM
Compound 3 ended at the assay's limit; the forecaster's own chance of this, stated with the estimate: 85%; middle value at least 1.1-fold (0.05 log units) from the limit.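

In this assay, for the compounds shown here, compound 1, compound 2 and compound 3 all give limits rather than numbers, so no step among them can be read. From the compounds shown here alone, whether ethyl in place of hydrogen changes the read-out at all stays open.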